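A few compounds are considered here, and "the series" means these few. Any claim that something is new, unique, unknown or untested is made for them only; others in the source may bear on it.

All four compounds share one core, and its structure stands beside each compound below. Compound 1 is `Cc1nc(-c2cccc(F)c2)c(C(=O)N2CCN(c3cccc(Cl)c3)CC2)o1` and compound 2 is `CCc1nc(-c2cccc(F)c2)c(C(=O)N2CCN(c3cccc(Cl)c3)CC2)o1`; they differ only in the length of one chain. In a functional assay on HL-60 cells (Homo sapiens) for inhibition, read by MTT assay, with a stated time of 72 h (a lower number here means a stronger inhibitor, a higher number a weaker inhibitor), compound 1 gives 33.7 nM, while compound 2 gives 317 nM. The change from compound 2 to compound 1 is hydrogen in place of methyl on a saturated chain carbon bound to an aromatic carbon, and it brings a 9.4-fold lower number from compound 2 to compound 1 (0.97 log units; beyond the scatter).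

Compound 3 is `CCCc1nc(-c2ccc(OC)cc2)c(C(=O)N2CCN(c3cccc(Cl)c3)CC2)o1`; it carries a methoxyphenyl group where compound 2 has a fluorophenyl group, and a longer chain. The difference between the cores of compound 3 and compound 2 is not broken down here. In this assay compound 3 gives "not active" (no number reported), with no number behind it.

Compound 4 is `CCc1nc(-c2ccc(OC)cc2)c(C(=O)N2CCN(c3cccc(Cl)c3)CC2)o1`. The change from compound 3 to compound 4 is hydrogen in place of methyl on a saturated chain carbon, two bonds along the chain from an aromatic carbon. Among the measured compounds shown here, this is the same kind of change as the one from compound 2 to compound 1, but not the same: there it sat on a saturated chain carbon bound to an aromatic carbon, here it sits two bonds along the chain from an aromatic carbon. Compound 3 gave no number in this assay. For the measured compounds named here, the only guide to the size of the step is the one seen from compound 2 to compound 1, and the chain of compound 4 matches that of compound 2, which gave 317 nM.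

Compound 4 is therefore expected to give about 1500 nM in this assay, within an estimated range from 300 nM to 10000 nM.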

Compound 4, half-maximal inhibitory concentration: > 1000 nM
Compound 4 was reported as a limit (the forecaster's own chance of this, stated with the estimate: 45%); the middle value is on the limit's open side.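

In this assay compound 4 is reported only as a limit, not as a number: the limit of > 1000 nM in this assay, at which 1 of the 4 values shown sits. With the ethyl chain held fixed, 4-methoxyphenyl in place of 3-fluorophenyl still brings an at least 3.1-fold higher number from compound 2 to compound 4 (0.49 log units; beyond the scatter), so on the ethyl compounds this swap gives a weaker inhibitor, and the true size of the step may be larger than the figure printed. The propyl to ethyl step between compound 3 and compound 4 cannot be read, as compound 3 has no number and compound 4 has only a limit, so these compounds do not show whether the gain seen with the 3-fluorophenyl group, a 9.4-fold lower number from compound 2 to compound 1 (0.97 log units; beyond the scatter), carries over to the 4-methoxyphenyl compounds.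

The clearest open case is a compound with a methyl chain and the 4-methoxyphenyl group, which would complete the set of chain and aryl pairings around compound 1 and show whether the two changes act independently. Also open, going by these compounds, is how an amine or a carboxylic acid in place of the methoxy group would behave in this assay, and whether any such compound would come back to a measurable number rather than a limit.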